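This account rests on a few compounds, and the source may have more. Where it says the series, first, only, none or still open, it means among the compounds named here.

Compound 3 `Cc1cccc(NC(=O)/N=C2\CCCN2C)c1` stands level with compound 2 `CN1CCC/C1=N\C(=O)Nc1cccc(Br)c1` in a functional assay on the whole organism with Rattus norvegicus as the target, with a stated time of 5 days; a higher number here means that more compound is needed for the effect, a lower number that less compound is needed: compound 3 gives 25 mg/kg, and compound 2 gives 25 mg/kg, together the highest of the three numbers measured, while compound 1 `CCN1CCC/C1=N\C(=O)Nc1cccc(Cl)c1` gives 15 mg/kg, a gap within the scatter. Compound 4 `CN1CCC/C1=N\C(=O)Nc1cccc(Cl)c1` is not yet measured. It differs from compound 3 by chloro in place of methyl on an aromatic carbon. Within the data shown here, the one step that bears on a change at this position is no change at the digits printed from compound 2 to compound 3 (within the scatter), so a halogen and a methyl behaved alike there. Compound 1 also carries chloro at this carbon, and its value of 15 mg/kg lies within the scatter of compound 3. A step of a 1.3-fold lower number from compound 3 to compound 4 (0.10 log units; within the scatter) is therefore expected, none beyond the scatter. In this assay compound 4 is estimated at 20 mg/kg, with a range of 10 mg/kg to 40 mg/kg.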

Compound 4, minimum effective dose: 15 mg/kg
Compound 4: the middle estimate sits 1.3-fold (0.12 log units) above what was measured; low and high end bracket the measured number.
By their numbers in this assay, from the lowest: compounds 1, 4, 2 and 3 (each within the scatter of the next).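

In this assay, chloro in place of methyl on the aromatic carbon gives a 1.7-fold lower number from compound 3 to compound 4 (0.22 log units; within the scatter), and chloro in place of bromo gives a 1.7-fold lower number from compound 2 to compound 4 (0.22 log units; within the scatter), so methyl, bromo and chloro are not told apart at this position. With chloro held fixed, hydrogen in place of methyl on the saturated chain carbon bound to the ring amine nitrogen gives no change at the digits printed from compound 1 to compound 4 (within the scatter), so that change is not told apart either. Nothing available explains these results. Going by these compounds, whether a carboxylic acid or an amine at this aromatic carbon, or a longer chain on the ring nitrogen, would give a step beyond the scatter remains open.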